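The source may hold more compounds than are shown below. What is called first, only, known or untested is meant among the compounds shown, and "the series" means these compounds.

In a functional assay on K562 cells (Homo sapiens) for inhibition, read by CCK-8 assay, with a stated time of 72 h (a lower number here means a stronger inhibitor, a higher number a weaker inhibitor), compound 1 `O=C(/C=C/c1cccnc1)NCCCCc1ccc(S(=O)(=O)Nc2ccccc2)cc1` gives 9.56 nM, compound 2 `O=C(/C=C/c1cccnc1)NCCCCCCc1ccc(S(=O)(=O)Nc2ccccc2)cc1` gives 48.5 nM and compound 3 `O=C(/C=C/c1cccnc1)NCCCCCCc1cccc(S(=O)(=O)Nc2ccccc2)c1` gives 0.88 nM. Compound 3 therefore has the lowest number of the three, beyond the usual scatter of repeated measurements, and is the strongest inhibitor so far. Compound 4 `CC(C)(C)c1ccc(NS(=O)(=O)c2cccc(CCCCCCNC(=O)/C=C/c3cccnc3)c2)cc1` differs from compound 3 in one place, with tert-butyl in place of hydrogen on an aromatic carbon. Going by the values given here, no measured compound carries a group there, so the data offer no direct guide. A small weakening is expected, given that compound 3 already reaches 0.88 nM. The estimated step is a 2.0-fold higher number from compound 3 to compound 4 (0.31 log units; beyond the scatter). For compound 4 the estimated value is 1.8 nM, with an expected range of 0.35 nM to 10 nM.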

Compound 4, half-maximal inhibitory concentration: 24.7 nM
Estimate against measurement, compound 4: 14-fold (1.14 log units) below, outside the stated range (above it).
By their numbers in this assay, from the lowest: compound 3; then compound 1; then compounds 4 and 2 (each within the scatter of the next).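

Changing anilino to (4-(tert-butyl)phenyl)amino gives a 28-fold higher number from compound 3 to compound 4 (1.45 log units; beyond the scatter) in this assay, a large loss of strength. Going by these compounds alone, this shows that the place is sensitive to substitution, which the earlier compounds could not show, as all of them carry hydrogen there. Nothing in the data explains the loss.

From the compounds shown here alone, whether methyl, fluorine or an amine at this same place would keep the strength of compound 3 remains open. So does whether tert-butyl would cost as much on compound 1 or compound 2.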